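Swapping a para group on a sulfonyl-aryl ring

The source may hold more compounds than are shown below. What is called first, only, known or untested is meant among the compounds shown, and "the series" means these compounds.

The compounds here share a core in which a sulfonyl-bearing aromatic ring carries one variable group, and they are compared in a functional assay on DLD-1 cells (Homo sapiens) for antiproliferative activity, read by CellTiter-Glo, with a stated time of 72 h; a higher number here means a weaker inhibitor, a lower number a stronger inhibitor. Compound 1 `CC1CCN(C2CCN(S(=O)(=O)c3cccc(Br)c3)CC2)CC1` gives 3.2 nM in this assay. Compound 3 `Cc1cc(C)cc(-c2cccc(S(=O)(=O)N3CCC(N4CCC(C)CC4)CC3)c2)c1` gives 41 nM in this assay, and the step of a 13-fold higher number from compound 1 to compound 3 (1.11 log units; beyond the scatter) shows that enlarging that group already costs activity. Compound 2 `CC1CCN(C2CCN(S(=O)(=O)c3ccc(C(C)(C)C)cc3)CC2)CC1` stands apart: in this assay compound 2 reaches only the limit of > 5000 nM, so no exact number is known for it, and it sits at the limit of > 5000 nM in this assay, at which 1 of the 3 values shown sits.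

Compound 4 `COC(=O)c1ccc(S(=O)(=O)N2CCC(N3CCC(C)CC3)CC2)cc1` is made from compound 2 by a single change, (methoxycarbonyl in place of tert-butyl on an aromatic carbon). Among the measured compounds shown here, the one measured step, from compound 1 to compound 3, concerns a different place on the ring and a different kind of exchange, so it bears only loosely here; the standing of compound 2 at the limit is the closest guide. Because compound 2 gives > 5000 nM, the starting point is itself unknown, and the expected step of an at least 2.5-fold lower number from compound 2 to compound 4 (0.39 log units; beyond the scatter) can only be a rough guess toward a measurable number. Compound 4 is therefore expected to give about 2000 nM in this assay, somewhere between 200 nM and 8000 nM.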

Compound 4, half-maximal inhibitory concentration: > 5000 nM
Compound 4: only a limit was reported (the forecaster's own chance of this, stated with the estimate: 40%); at least 2.5-fold (0.39 log units) between middle value and limit.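

In this assay compound 4 gives > 5000 nM, which is a limit and not a number. Compound 2 also stands only at a limit, so no step between compound 2 and compound 4 can be read: the limit of > 5000 nM in this assay, at which 2 of the 4 values shown sit.

The compounds shown leave open how far each lies past that limit, and so whether methoxycarbonyl and tert-butyl differ at all on that aromatic carbon.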